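Porcupine inhibitors: opening notes on a mixed set

This account rests on a few compounds, and the source may have more. Where it says the series, first, only, none or still open, it means among the compounds named here.

Measured compounds:
- compound 1, `O=C(CNC(=O)c1nn(-c2ccccc2)c(=O)c2ccccc12)Nc1nc2ccc(F)cc2s1`, 470 nM
- compound 2, `COc1ccc(-n2nc(C(=O)NCC(=O)Nc3nc4ccccc4s3)c3ccccc3c2=O)cc1`, 25000 nM
- compound 3, `CN(C)c1ccc(NC(=O)CSc2nc3c(c(=O)n2-c2ccccc2)SCC3)cc1`, > 1000 nM

Three compounds have been run in an assay on L cells for inhibition of Protein-serine O-palmitoleoyltransferase porcupine (Mus musculus), read by reporter gene assay, with a stated time of 24 h; on this read-out lower numbers stand for an effect already at smaller amounts and higher numbers for an effect only at larger amounts of compound. Among the compounds with values here, compound 1 gives 470 nM and compound 2 gives 25000 nM; the two share a core but nothing else that can be compared in a single step, so only the pair of values is noted. For compound 3 the value is a limit of the assay, not a number: the limit of > 1000 nM in this assay, at which 1 of the 3 values shown sits. Compound 3 therefore cannot be placed against compound 1 or compound 2 beyond saying that it did not reach the read-out within the range tested.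

The next compound, compound 4, `O=C(CSc1nc2c(c(=O)n1-c1ccccc1)SCC2)Nc1ccc(-c2ccccc2)cc1`, keeps the core of compound 3 and changes one group: phenyl in place of dimethylamino on an aromatic carbon. Within the data shown here, no measured pair in this set changes the same group, so there is no step to lean on. Since compound 3 only sets a limit, the direction from compound 3 to compound 4 is open; the working expectation is that compound 4 stays weak, with the step from compound 3 to compound 4 expected as a step that the limit leaves unreadable from compound 3 to compound 4. For compound 4 in this assay the estimate is 3000 nM, with a range from 600 nM to 15000 nM.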

Compound 4, half-maximal effective concentration: 0.75 nM
For compound 4 the middle estimate is 4000-fold (3.60 log units) above the measured one, and the stated range ends above it.
By their numbers in this assay, from the lowest: compound 4; then compound 1; then compound 2.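

In this assay, within the data shown here, phenyl in place of dimethylamino on an aromatic carbon, para to a large group, gives the first single-place comparison in this set, and the result is an at least 1300-fold lower number from compound 3 to compound 4 (3.12 log units; beyond the scatter). This position is shown not to be indifferent to what it carries: with the change, which brings in one six-membered aromatic ring of carbon only and takes out one hydrogen-bond acceptor, compound 4 reads 0.75 nM. Compound 3 is held by a limit of the assay and not by a number, so this step is a lower bound and its full size is unknown: the limit of > 1000 nM in this assay, at which 1 of the 4 values shown sits.

From the compounds shown here alone, this single pair cannot separate the effect of the added ring from that of the lost acceptor, and it remains open how the read-out responds at this position to a small group such as methoxy, to a saturated ring such as cyclohexyl, or to a pyridine ring. Also open, going by these compounds, is whether a phenyl carrying a carboxylic acid or an amine would hold the value of compound 4.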